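A few compounds are considered here, and "the series" means these few. Any claim that something is new, unique, unknown or untested is made for them only; others in the source may bear on it.

Of the compounds shown here, two sharing one core have been tested in an assay (Oryctolagus cuniculus) for binding affinity to platelet-activating factor receptor (Cavia porcellus); a lower number here means that less compound is needed, a higher number that more compound is needed for the effect. Compound 1 `COc1cc(C(=O)N2CCN(C(=O)c3cc(OC)c(OC)c(OC)c3)C(COC(=O)C(C)(C)C)C2)cc(OC)c1OC` gives 300 nM; 300 nM; 420 nM (3 entries) in this assay, and its repeated entries, (the several entries of compound 1 in this assay, 300 nM; 300 nM; 420 nM (3 entries)), lie close together. Going by the values given here, compound 2 `CCCCNC(=O)OCC1CN(C(=O)c2cc(OC)c(OC)c(OC)c2)CCN1C(=O)c1cc(OC)c(OC)c(OC)c1` gives 700 nM in this assay; this is the only number known for it, beside one further entry that carries no single number. Compound 3 `CCCN(CCC)C(=O)OCC1CN(C(=O)c2cc(OC)c(OC)c(OC)c2)CCN1C(=O)c1cc(OC)c(OC)c(OC)c1` has not been measured in this assay. It differs from compound 2 in one place: dipropylamino in place of butylamino on a carbonyl carbon. Among the compounds with values here, no pair of measured compounds that differ in a single place is available, so the size of this step can only be guessed. The expected step of a 1.1-fold lower number from compound 2 to compound 3 (0.03 log units; within the scatter) is small, hardly more than the usual scatter, in either direction. For compound 3 the estimate in this assay is 650 nM, with a likely range from 220 nM to 2000 nM.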

Compound 3, half-maximal effective concentration: 680 nM
Compound 3: the middle estimate sits 1.0-fold (0.02 log units) below what was measured, within the range that was stated.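

In this assay, going by these compounds alone, this is the first step that can be read between two compounds differing in one place: a 1.0-fold lower number from compound 2 to compound 3 (0.01 log units; within the scatter), with dipropylamino in place of butylamino on a carbonyl carbon. The entering group has 7 heavy atoms against 5 and no hydrogen-bond donor against 1, yet the step stays within the scatter, so at this position these two groups cannot be told apart in this assay. The repeated entries of one compound spread wider than this step: the several entries of compound 1 in this assay, 300 nM; 300 nM; 420 nM (3 entries).

Still open, as far as these compounds go, is how a quite different group would fare at this carbonyl carbon, such as piperidine, a ring amine, or dihexylamino, with much longer chains. A single step also cannot show whether the hydrogen-bond donor matters when the chains stay the same.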